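Furan-2-yl to thiophen-2-yl on the shared core

The source may hold more compounds than are shown below. What is called first, only, known or untested is meant among the compounds shown, and "the series" means these compounds.

Measured in a functional assay on U-251 cells (Homo sapiens) for antiproliferative activity, read by MTT assay, with a stated time of 48 h; on this read-out lower numbers stand for stronger inhibition and higher numbers for weaker inhibition:
- compound 1 `COc1ccc(-c2nc3cccc(-c4cc(OC)c(OC)c(OC)c4)c3o2)cc1`: > 25000 nM, a limit of the assay and not a number
- compound 2 `COc1cc(-c2cccc3nc(-c4cccc(Br)c4)oc23)cc(OC)c1OC`: 6800 nM
- compound 3 `COc1cc(-c2cccc3nc(-c4ccco4)oc23)cc(OC)c1OC`: 10600 nM

Compound 3 at 10600 nM lies within the scatter of compound 2, as a 1.6-fold higher number from compound 2 to compound 3 (0.19 log units; within the scatter) shows. The next change gives compound 4 `COc1cc(-c2cccc3nc(-c4cccs4)oc23)cc(OC)c1OC`: thiophen-2-yl in place of furan-2-yl on an aromatic carbon. Three measured steps swap the group on this carbon. The closest is a 1.6-fold higher number from compound 2 to compound 3 (0.19 log units; within the scatter), which stays within the scatter. Leaving 4-methoxyphenyl gave larger steps, an at least 3.6-fold lower number from compound 1 to compound 2 (0.56 log units; beyond the scatter) and an at least 2.3-fold lower number from compound 1 to compound 3 (0.37 log units; beyond the scatter). No step beyond the scatter is expected here, and the estimate is a 1.2-fold lower number from compound 3 to compound 4 (0.07 log units; within the scatter). The estimated value for compound 4 is 9000 nM, with an expected range of 4500 nM to 18000 nM.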

Compound 4, half-maximal inhibitory concentration: 3000 nM
Beside the measured number, compound 4's estimate is 3.0-fold (0.48 log units) above it; measured number outside the range, below it.
By their numbers in this assay, from the lowest: compound 4; then compounds 2 and 3 (each within the scatter of the next). At a limit, above all of these: compound 1.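

Exchanging one five-membered aromatic ring for another on this carbon is not a silent change in this assay (a 3.5-fold lower number from compound 3 to compound 4 (0.55 log units; beyond the scatter)), although only sulfur replaces oxygen. Thiophen-2-yl also separates from 3-bromophenyl (a 2.3-fold lower number from compound 2 to compound 4 (0.36 log units; beyond the scatter)), a gap the furan-2-yl compound did not show, and it gives the widest step from 4-methoxyphenyl (an at least 8.3-fold lower number from compound 1 to compound 4 (0.92 log units; beyond the scatter)). That last step is only a bound, as compound 1 stands at a limit and not a number: the limit of > 25000 nM in this assay, at which 1 of the 4 values shown sits.

On these data alone, whether a substituted thiophene keeps this gain remains open. So does the outcome with an amine or a carboxylic acid on this carbon.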